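A few compounds are considered here, and "the series" means these few. Any claim that something is new, unique, unknown or untested is made for them only; others in the source may bear on it.

Measured in a physicochemical assay for lipophilicity, measured as octanol-water partition, at pH 7.4; a lower number here means a more polar compound, a higher number a more lipophilic compound:
- compound 1 `Cc1ccc(Cn2c(=O)[nH]c3c(N)nc(C(F)(F)F)cc32)nn1`: 1.1
- compound 2 `Cc1nc(Cn2c(=O)[nH]c3c(N)nc(C(F)(F)F)cc32)cs1`: 2.3
- compound 3 `Cc1nc(Cn2c(=O)[nH]c3c(N)nc(C(F)(F)F)cc32)co1`: 1.7

Compound 3 holds the middle place of the three numbers. Below it lies compound 1, with a number 0.60 log units higher from compound 1 to compound 3 (beyond the scatter). Above it lies compound 2, and the step down is a number 0.60 log units lower from compound 2 to compound 3 (beyond the scatter).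

Compound 4 `COc1ccc(Cn2c(=O)[nH]c3c(N)nc(C(F)(F)F)cc32)cn1` carries 6-methoxypyridin-3-yl in place of 2-methyl-1,3-oxazol-4-yl on a saturated chain carbon bound to an aromatic nitrogen.

All three measured steps are swaps at this same place, and the widest is a number 1.20 log units higher from compound 1 to compound 2 (beyond the scatter). None of them involves the entering group, so they show only how far such a swap can move the number. The entering group is the larger one, which suggests a modest rise in this assay. Size alone is a weak guide, however, since compound 1 has a six-membered ring yet gives only 1.1.

The expected change is a number 0.50 log units higher from compound 3 to compound 4 (beyond the scatter). The estimate for compound 4 is 2.2, with an expected range of 1.6 to 2.8.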

Compound 4, distribution coefficient: 2.8
Beside the measured number, compound 4's estimate is 0.60 log units below it; the range from low to high includes it.
By their numbers in this assay, from the lowest: compound 1; then compound 3; then compound 2; then compound 4.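

In this assay, 6-methoxypyridin-3-yl on this saturated chain carbon bound to an aromatic nitrogen gives the highest number of the four compounds, passing both the 2-methyl-1,3-oxazol-4-yl group (a number 1.10 log units higher from compound 3 to compound 4 (beyond the scatter)) and the 2-methyl-1,3-thiazol-4-yl group (a number 0.50 log units higher from compound 2 to compound 4 (beyond the scatter)). The widest step at this place is now the one between two six-membered aromatic rings (a number 1.70 log units higher from compound 1 to compound 4 (beyond the scatter)), so ring size alone does not set the number here, and the choice of ring and its substituent can count for more than the change from a five-membered to a six-membered ring. Nothing in the data gives a reason for these differences.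

Still open, going by these compounds, is how much of the rise belongs to the methoxy group and how much to the pyridine ring, which come together in compound 4. A 6-methylpyridin-3-yl group or a plain phenyl ring at this place would help to separate the two.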